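Long-chain triazole esters as IL15 receptor inhibitors

The source may hold more compounds than are shown below. What is called first, only, known or untested is meant among the compounds shown, and "the series" means these compounds.

The measured compounds:
compound 1 `Cn1c(Cc2nn(C)c(=O)c3ccccc23)nnc1SCCCCCCCCCCC(=O)Nc1ccc(Cl)cc1`, 20000 nM
compound 2 `Cn1c(Cc2nn(C)c(=O)c3ccccc23)nnc1SCCCCCCCC(=O)Nc1ccc(O)cc1O`, 17000 nM
compound 3 `COc1ccc(NC(=O)CSc2nnc(Cc3nn(C)c(=O)c4ccccc34)n2C)cc1`, "not active" (no number reported)

In an assay on isolated protein (Mus musculus) for inhibition of IL15-IL15 receptor (Homo sapiens), read by resazurin assay, with stated times of 30 min and 2.5 days (a higher number here means a weaker inhibitor, a lower number a stronger inhibitor), compound 2 gives 17000 nM, the lowest of the two numbers reported. Its nearest neighbour is compound 1, whose 20000 nM lies within the usual scatter, so the two cannot be ordered. For compound 3 this assay reported "not active" (no number reported) and no number. For the measured compounds named here, no pair of measured compounds differs in a single place, so no measured step is available to calibrate the change ahead.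

Compound 4 `Cn1c(Cc2nn(C)c(=O)c3ccccc23)nnc1SCCCCCCCC(=O)Oc1ccc(Cl)cc1Cl` is the unmeasured compound. It departs from compound 2 by 2,4-dichlorophenoxy in place of (2,4-dihydroxyphenyl)amino on a carbonyl carbon. Because the values of compound 2, 17000 nM, and compound 1, 20000 nM, are both weak and alike despite their differing chain ends, the expected step of a 1.5-fold higher number from compound 2 to compound 4 (0.17 log units; within the scatter) in this assay is small, likely no larger than the scatter, with a lean toward a weaker number given the loss of all hydrogen-bond donors. The estimate for compound 4 in this assay is therefore 25000 nM, within a range from 8000 nM to 80000 nM.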

Compound 4, half-maximal inhibitory concentration: 800 nM
For compound 4 the middle estimate is 31-fold (1.49 log units) above the measured one; the measured number lies below the stated range.
By their numbers in this assay, from the lowest: compound 4; then compounds 2 and 1 (each within the scatter of the next).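

In this assay, putting 2,4-dichlorophenoxy in place of (2,4-dihydroxyphenyl)amino on a carbonyl carbon gives a 21-fold lower number from compound 2 to compound 4 (1.33 log units; beyond the scatter), so this position can move the value well beyond the scatter, which the earlier compounds had not shown. The new group carries no hydrogen-bond donors, while the group it replaces carries them, and the gain comes with an oxygen instead of a nitrogen on the carbonyl carbon and with chlorines instead of hydroxyls on the ring. Nothing measured here accounts for the size of this step.

Going by these compounds, whether the gain follows the oxygen on the carbonyl carbon or the two chlorines on the ring remains open, and a (2,4-dichlorophenyl)amino group at this place would separate the two. Also unsettled is how the value would respond to a free carboxylic acid at this carbonyl carbon, or to a longer chain with 2,4-dichlorophenoxy kept in place.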